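From nitro to chloro: compound 1 and compound 4

The source may report more compounds than this note shows. Statements on the series, on what has been measured and on what is new or still open speak of the compounds shown alone.

Measured so far in a functional assay on MCF7 cells (Homo sapiens) for antiproliferative activity, read by MTT assay; a higher number here means a weaker inhibitor, a lower number a stronger inhibitor:
compound 1 `COc1ccc(-c2ccnc(Nc3ccc([N+](=O)[O-])cc3)n2)cc1` gives 770 nM
compound 2 `O=[N+]([O-])c1ccc(Nc2nccc(-c3ccc(F)cc3)n2)cc1` gives 400 nM
compound 3 `O=[N+]([O-])c1ccc(Nc2nccc(-c3ccc(Cl)c(Cl)c3)n2)cc1` gives 3510 nM

The scatter does not separate the first two entries: a 1.9-fold lower number from compound 1 to compound 2 (0.28 log units; within the scatter). The dichlorinated entry stands clearly apart: a 4.6-fold higher number from compound 1 to compound 3 (0.66 log units; beyond the scatter). Compound 4 `COc1ccc(-c2ccnc(Nc3ccc(Cl)cc3)n2)cc1` changes a different part of the structure of compound 1, with chloro in place of nitro on an aromatic carbon. Among the measured compounds shown here, all three measured compounds keep the nitro group, so no measured step tests this change directly. The steps measured elsewhere give only a rough guide to size, the largest being an 8.8-fold higher number from compound 2 to compound 3 (0.94 log units; beyond the scatter). Compound 1 at 770 nM already lies near the low end of the numbers seen, so a modest move to a higher number is expected, though the direction remains uncertain. The expected change is a 2.3-fold higher number from compound 1 to compound 4 (0.37 log units; beyond the scatter). For compound 4 the estimated value in this assay is 1800 nM, with an expected range from 350 nM to 9000 nM.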

Compound 4, half-maximal inhibitory concentration: 810 nM
Beside the measured number, compound 4's estimate is 2.2-fold (0.35 log units) above it; measured number inside the range.
By their numbers in this assay, from the lowest: compounds 2, 1 and 4 (each within the scatter of the next, the first and the last beyond it); then compound 3.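

In this assay, among the compounds shown here, this is the first measured change at the position para to a large group, and it gives a 1.1-fold higher number from compound 1 to compound 4 (0.02 log units; within the scatter). With the 4-methoxyphenyl group held constant, chloro can therefore stand in place of nitro without a difference that the scatter can separate, even though the hydrogen-bond acceptors counted on the nitro group leave with it. Nothing available explains why this pair of compounds gives such similar numbers.

The compounds shown leave open whether chloro in place of nitro would behave in the same way with the 4-fluorophenyl group of compound 2 or the 3,4-dichlorophenyl group of compound 3. They also leave open how an amine or a nitrile at this position would compare.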